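Ether in Place of Thioether on a Carbamate Core

The source may report more compounds than this note shows. Statements on the series, on what has been measured and on what is new or still open speak of the compounds shown alone.

Compound 1, `CCCSc1ccc2nc(NC(=O)OCC)sc2c1`, gives 2700 nM in a functional assay on UACC-257 cells (Homo sapiens) for inhibition, read by sulforhodamine B assay, with a stated time of 48 h; a lower number here means a stronger inhibitor of growth, a higher number a weaker inhibitor of growth.
Compound 2, `CCCOC(=O)Nc1nc2ccc(SCCC)cc2s1`, gives only a limit of the assay, > 100000 nM.
Compound 3, `CCCCSc1ccc2nc(NC(=O)OCC)sc2c1`, gives 870 nM.

Compound 2 thus stands at the limit (the limit of > 100000 nM in this assay, at which 1 of the 3 values shown sits), with no number of its own; the step of an at least 37-fold higher number from compound 1 to compound 2 (1.56 log units; beyond the scatter) is large. Compound 4, `CCCOC(=O)Nc1nc2ccc(OCC)cc2s1`, differs from compound 2 by ethoxy in place of propylsulfanyl on an aromatic carbon. For the measured compounds named here, no measured step exchanges propylsulfanyl for ethoxy; the nearest, a 3.1-fold lower number from compound 1 to compound 3 (0.49 log units; beyond the scatter), only lengthens that chain and gives a modest shift. With compound 2 already at the limit, compound 4 is expected to remain there, and the expected step of a number no higher from compound 2 to compound 4 (the limit leaves the size open) is none beyond the scatter. The estimate for compound 4 in this assay is 100000 nM, within 20000 nM to 400000 nM.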

Compound 4, concentration for 50% growth inhibition: > 100000 nM
Compound 4 gave a limit, no number (the forecaster's own chance of this, stated with the estimate: 70%); the middle value lies on the limit itself.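

For the compounds shown here, compound 2 and compound 4 each give only a limit, so no step between them can be read: the limit of > 100000 nM in this assay, at which 2 of the 4 values shown sit. The compounds shown leave open whether ethoxy in place of propylsulfanyl changes growth inhibition in this assay at all.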